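The source may report more compounds than this note shows. Statements on the series, on what has been measured and on what is new or still open speak of the compounds shown alone.

Measured in a functional assay on HT-29 cells (Homo sapiens) for inhibition, read by luminescence and CellTiter-Glo, with a stated time of 24 h; a higher number here means that more compound is needed for the effect, a lower number that less compound is needed:
- compound 1 `CN1C(=S)[C@@H](NC(=O)c2nc(Cc3ccccc3)n(CCCCCC#N)n2)COc2ccccc21`: 3830 nM
- compound 2 `CN1C(=S)[C@@H](NC(=O)c2nc(Cc3ccccc3)n(C3CCC3)n2)COc2ccccc21`: 181 nM

Of these two, compound 2 has the lower number, at 181 nM. The next change leads to compound 3 `CN1C(=S)[C@@H](NC(=O)c2nc(Cc3ccccc3)n(C3CCOC3)n2)COc2ccccc21`, with oxolan-3-yl in place of cyclobutyl on an aromatic nitrogen.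

Among the compounds with values here, one measured step bears on this: a 21-fold lower number from compound 1 to compound 2 (1.33 log units; beyond the scatter). It is large and beyond the scatter, and it shows that the group on this aromatic nitrogen can shift the number strongly in this assay. Within the data shown here, it does not test a ring with a hetero atom, and no measured compound carries one at this place, so the size of the next step is poorly constrained. Among the measured compounds shown here, the only measured group here with a hetero atom is the nitrile-bearing 5-cyanopentyl of compound 1, at 3830 nM. That gives a weak lean towards a higher number, and a step far smaller than the measured one is expected. The expected step is a 1.9-fold higher number from compound 2 to compound 3 (0.29 log units; within the scatter). For compound 3 the estimated value is 350 nM, with an expected range of 110 nM to 1100 nM.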

Compound 3, half-maximal effective concentration: 1580 nM
Estimate against measurement, compound 3: 4.5-fold (0.65 log units) below; the measured number lies above the stated range.
By their numbers in this assay, from the lowest: compound 2; then compound 3; then compound 1.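

In this assay, oxolan-3-yl in place of cyclobutyl on the aromatic nitrogen gives an 8.7-fold higher number from compound 2 to compound 3 (0.94 log units; beyond the scatter), so a non-aromatic ring of 4 carbon at this place does not by itself keep the number low; the change adds an oxygen and enlarges the ring from four-membered to five-membered, and this single step cannot tell these two differences apart. Oxolan-3-yl in place of 5-cyanopentyl gives a 2.4-fold lower number from compound 1 to compound 3 (0.38 log units; beyond the scatter), so among the three groups the number rises from cyclobutyl through oxolan-3-yl to 5-cyanopentyl, and the ring with a hetero atom does not match cyclobutyl even though it improves on the long nitrile-bearing chain. Nothing available accounts for the size of either step.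

The compounds shown leave open whether the oxygen or the ring size matters more, a question that cyclopentyl and oxetan-3-yl at this nitrogen would help to separate. Also open, on these data alone, is how a ring carrying an amine, such as pyrrolidin-3-yl, or a small open chain such as isopropyl, would compare with cyclobutyl here.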